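Aryl variation on the amine nitrogen, compounds 1 to 4

The compounds below may be only part of what the source reports. "The series", "measured", "known", "first", "only" and "open" are said of these compounds alone.

Measured compounds in a functional assay on HeLa cells (Homo sapiens) for cytotoxicity, read by MTT assay, with a stated time of 48 h; a higher number here means a weaker inhibitor, a lower number a stronger inhibitor:
compound 1 `COc1ccc(N/C(CCNC2=CC(=O)c3ccccc3C2=O)=N\S(=O)(=O)c2ccc(C)cc2)cc1` gives 7590 nM
compound 2 `Cc1ccc(S(=O)(=O)/N=C(/CCNC2=CC(=O)c3ccccc3C2=O)Nc2ccc(F)cc2)cc1` gives 5890 nM
compound 3 `Cc1ccc(S(=O)(=O)/N=C(/CCNC2=CC(=O)c3ccccc3C2=O)Nc2ccccc2[N+](=O)[O-])cc1` gives 3310 nM

Compound 1 stands at the highest of the three numbers in this assay. Its step to compound 2, a 1.3-fold lower number from compound 1 to compound 2 (0.11 log units; within the scatter), is within the scatter, so the two cannot be ordered. Its step to compound 3, a 2.3-fold lower number from compound 1 to compound 3 (0.36 log units; beyond the scatter), is a modest lowering that does pass the scatter. The step of a 1.8-fold lower number from compound 2 to compound 3 (0.25 log units; within the scatter) is again within the scatter.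

Compound 4 `Cc1ccc(S(=O)(=O)/N=C(/CCNC2=CC(=O)c3ccccc3C2=O)Nc2cccc(C)c2)cc1` differs from compound 1 as follows: 3-methylphenyl in place of 4-methoxyphenyl on an amine nitrogen. Both measured steps out of compound 1 concern the same aryl group on the same nitrogen, so both bear on this change. The closest parallel is the swap of the 4-methoxyphenyl substituent for a fluoro, a 1.3-fold lower number from compound 1 to compound 2 (0.11 log units; within the scatter), which moved the number only within the scatter; the larger step of a 2.3-fold lower number from compound 1 to compound 3 (0.36 log units; beyond the scatter) came with a 2-nitrophenyl group and is not repeated here. Among the measured compounds shown here, for 3-methylphenyl no measured step exists, so a change no larger than the scatter, leaning slightly lower, is expected in this assay: compound 4 is expected to give 6000 nM, with a range of 3000 nM to 12000 nM, an estimated step of a 1.3-fold lower number from compound 1 to compound 4 (0.10 log units; within the scatter).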

Compound 4, half-maximal inhibitory concentration: 9060 nM
For compound 4 the middle estimate is 1.5-fold (0.18 log units) below the measured one, and the stated range covers the measured number.
By their numbers in this assay, from the lowest: compounds 3, 2, 1 and 4 (each within the scatter of the next, the first and the last beyond it).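

Within this assay the swap to 3-methylphenyl on the amine nitrogen stays within the scatter, both from 4-methoxyphenyl (a 1.2-fold higher number from compound 1 to compound 4 (0.08 log units; within the scatter)) and from 4-fluorophenyl (a 1.5-fold higher number from compound 2 to compound 4 (0.19 log units; within the scatter)), so compound 4 cannot be ordered against compound 1 or compound 2. Among the compounds shown here, the only new step that passes the scatter is the modest one from 2-nitrophenyl to 3-methylphenyl (a 2.7-fold higher number from compound 3 to compound 4 (0.44 log units; beyond the scatter)), which makes compound 3 and compound 4 the widest-spaced pair so far, although compound 2 remains within the scatter of both. No measurement on hand accounts for the spread of these numbers.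

The compounds shown leave open whether a carboxylic acid or a dimethylamino group on this aryl ring would move the number further than 2-nitrophenyl did, and whether the separation of compound 3 belongs to the nitro group itself or to its place on the ring. For the compounds shown here, they also leave open how a longer chain in the shared core would read, since every step so far concerns the aryl group on the amine nitrogen.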